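The source may report more compounds than this note shows. Statements on the series, on what has been measured and on what is new or still open speak of the compounds shown alone.

Compound 1 `Cc1c(O)ccc2c1[C@H](Cn1cc(-c3ccccc3)nn1)[C@@]13CC(=O)[C@@](C)(CC[C@@H]21)C3` carries a free hydroxy on its aromatic ring. In a functional assay on MCF7 cells (Homo sapiens) for cytotoxicity, read by MTT assay, with a stated time of 4 days (a lower number here means a stronger inhibitor, a higher number a weaker inhibitor), compound 1 gives only a limit, > 20000 nM. Compound 2 `Cc1ccc(S(=O)(=O)Oc2ccc3c(c2C)[C@H](Cn2cc(-c4ccccc4)nn2)[C@@]24CC(=O)[C@@](C)(CC[C@@H]32)C4)cc1` differs from it by (4-methylphenyl)sulfonyl in place of hydrogen on an oxygen on an aromatic ring. In this assay compound 2 likewise gives only a limit, > 20000 nM. The step that the two limits leave unreadable from compound 1 to compound 2 therefore cannot be sized, because of the limit of > 20000 nM in this assay, at which 2 of the 3 values shown sit. Compound 3 `C=C1C(=O)[C@]23C[C@@]1(O)CC[C@H]2c1ccc(O)c(C)c1[C@@H]3Cn1cc(-c2ccc(F)cc2)nn1` is built on a different core, and the difference between the two cores is not broken down here. In this assay, among the compounds with values here, compound 3 gives 1700 nM, the only numeric value among the three measured compounds. Compound 4 `C=C1C(=O)[C@]23C[C@@]1(O)CC[C@H]2c1ccc(OS(=O)(=O)c2ccc(C)cc2)c(C)c1[C@@H]3Cn1cc(-c2ccc(F)cc2)nn1` is not yet measured; it differs from compound 3 by (4-methylphenyl)sulfonyl in place of hydrogen on an oxygen on an aromatic ring, the same change as that from compound 1 to compound 2, made at the same kind of place. Since the measured instance of this change gives no readable size, the expected step of a 2.4-fold higher number from compound 3 to compound 4 (0.37 log units; beyond the scatter) rests only on the numeric value of compound 3 and is held close to it. Compound 4 is therefore estimated at 4000 nM, with a range from 1000 nM to 20000 nM.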

Compound 4, half-maximal inhibitory concentration: 330 nM
Beside the measured number, compound 4's estimate is 12-fold (1.08 log units) above it, and the stated range ends above it.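

On the core of compound 3, (4-methylphenyl)sulfonyl in place of hydrogen on an oxygen on an aromatic ring gives a 5.2-fold lower number from compound 3 to compound 4 (0.71 log units; beyond the scatter) in this assay, so the change has a readable size on this core. The same change on the core of compound 1 cannot be read, and so offers no size to set against it, because neither value there is a number: the limit of > 20000 nM in this assay, at which 2 of the 4 values shown sit. The series therefore holds one readable instance of the change, which shows neither that it carries across the two cores nor that it behaves differently on them.

The compounds shown leave open whether the step on the core of compound 3 is particular to (4-methylphenyl)sulfonyl or would also appear with methanesulfonyl, acetyl or methyl on that oxygen. They also leave open what an amine or a carboxylic acid in place of the methyl of that group would do in this assay.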